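The compounds below may be only part of what the source reports. "The series", "measured", "known", "first", "only" and "open" are said of these compounds alone.

Three compounds share one fused core, and compound 3, `Cc1nc2c(/C=C/c3ccccc3)cccn2c1C`, stands at the top of the numbers gathered so far. In a functional assay on the whole organism for inhibition, with Rattus norvegicus as the target, with a stated time of 1 h (on this read-out lower numbers stand for an effect already at smaller amounts and higher numbers for an effect only at larger amounts of compound), compound 3 gives 10.4 mg/kg. Compound 2, `Cc1nc2c(OCc3ccccc3)cccn2c1C`, gives 10 mg/kg in this assay, a number that sits within the scatter of the value for compound 3. Compound 1, `Cc1nc2c(OCc3ccccc3)nccn2c1N`, gives 5 mg/kg in this assay, and here the gap to compound 3 lies beyond the scatter, so compound 3 takes effect only at a larger dose than compound 1.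

The next compound, compound 4, `Cc1nc2c(/C=C/c3ccccc3)cccn2c1N`, keeps the styryl part of compound 3 and differs from it in a single place: amino in place of methyl on an aromatic carbon. Among the compounds with values here, no pair already measured differs in this one place alone, so the size of the coming step has to be guessed from looser hints. Compound 1 carries an amino group in the same spot and gives 5 mg/kg, while compound 2, which carries a methyl group there, gives 10 mg/kg, but these two compounds differ in their six-membered ring as well, so the hint is weak.

For compound 4 the step from compound 3 is expected to be small and downward, a 1.5-fold lower number from compound 3 to compound 4 (0.17 log units; within the scatter), with a fair chance that it stays within the scatter. The estimate for compound 4 in this assay is therefore 7 mg/kg, expected to fall between 3 mg/kg and 15 mg/kg.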

Compound 4, dose for half-maximal effect: 13 mg/kg
Compound 4: middle estimate off by 1.9-fold (0.27 log units), on the low side; the range from low to high includes it.
By their numbers in this assay, from the lowest: compounds 1, 2, 3 and 4 (each within the scatter of the next, the first and the last beyond it).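

With the styryl part held fixed, amino in place of methyl on the aromatic carbon of the five-membered ring gives a 1.3-fold higher number from compound 3 to compound 4 (0.10 log units; within the scatter) in this assay. Within the data shown here, this is the first reading of the change on its own, since the earlier compounds offered no pair that differs in this one place alone, and it shows that, in this setting, the exchange of one heavy atom, which adds a hydrogen-bond donor and a hydrogen-bond acceptor, does not move the dose beyond what repeated measurements would scatter. No measurement at hand bears on why the read-out stays so close across this change.

Among these compounds, it remains open whether the same exchange would read alike with the benzyloxy group of compound 1 and compound 2 in place of the styryl part, as only one pair carries this change. Also open, going by these compounds, is how this carbon responds to groups other than these two, such as a plain hydrogen, a hydroxyl, a dimethylamino group, an acetamido group or a longer chain such as propyl.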